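Methyl in Place of Hydrogen and Vero Cell Cytotoxicity

The compounds below may be only part of what the source reports. "The series", "measured", "known", "first", "only" and "open" are said of these compounds alone.

Compound 1 `CCc1nc2ccccc2n1CCCCOc1cccc(Cl)c1` and compound 2 `CCc1nc2ccccc2n1CCCCOc1ccc(C)c(Cl)c1` were both examined in an ADME assay on Vero cells (Chlorocebus sabaeus) for cytotoxicity, read by luminescence, with a stated time of 2 days; on this read-out higher numbers stand for lower toxicity in this test and lower numbers for higher toxicity in this test. Compound 1 gives 22 uM and compound 2 gives 14 uM. The change between them is methyl in place of hydrogen on an aromatic carbon, and the step it made was a 1.6-fold lower number from compound 1 to compound 2 (0.20 log units; within the scatter). Compound 3 `CCc1nc2ccc(C)cc2n1CCCCNc1ccccc1` rests on a different core from compound 1; the difference between the two cores is not broken down here. In this assay compound 3 gives 21 uM, a value lying within the scatter of both compound 1 and compound 2. Compound 4 `CCc1nc2ccc(C)cc2n1CCCCNc1ccc(C)cc1` has not yet been measured. It differs from compound 3 by methyl in place of hydrogen on an aromatic carbon. This is the same kind of change as that from compound 1 to compound 2, though not the same: in compound 2 the place is also ortho to a chloro group, which the place in compound 4 is not. Because a 1.6-fold lower number from compound 1 to compound 2 (0.20 log units; within the scatter) stayed within the scatter, the step from compound 3 to compound 4 is expected to be similarly small, a 1.3-fold lower number from compound 3 to compound 4 (0.12 log units; within the scatter). Compound 4 is therefore estimated at 16 uM in this assay, with a likely range from 8 uM to 34 uM.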

Compound 4, half-maximal toxic concentration: 20 uM
For compound 4 the middle estimate is 1.3-fold (0.10 log units) below the measured one; measured number inside the range.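

In this assay, methyl in place of hydrogen on an aromatic carbon gave a 1.1-fold lower number from compound 3 to compound 4 (0.02 log units; within the scatter). Set beside the earlier step, the change shows no difference that can be told apart between the two cores: the same change on two cores in this assay, a 1.6-fold lower number (0.20 log units; within the scatter) from compound 1 to compound 2 and a 1.1-fold lower number (0.02 log units; within the scatter) from compound 3 to compound 4, 1.5-fold (0.18 log units) apart, within the scatter of two such steps. This shows that, in these two pairs, the methyl left the number within the scatter on both cores, but two pairs do not establish a rule for the series, and the surroundings of the methyl are not the same in them, as compound 2 also carries a chloro group.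

The compounds shown leave open whether a different group at the same place on the phenyl ring, such as a carboxylic acid, an amine or trifluoromethyl, would take the number beyond the scatter in this assay. They also leave open whether the methyl would behave alike on a core with a longer chain.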